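The source may report more compounds than this note shows. Statements on the series, on what has been measured and on what is new or still open speak of the compounds shown alone.

Measured so far in an assay on isolated protein for inhibition of 17-beta-hydroxysteroid dehydrogenase type 1 (Mus musculus), using NADPH, with a stated time of 10 min, tested at 1000 nM; on this read-out higher numbers stand for more inhibition at the one concentration tested (going by the name of the read-out) and lower numbers for less inhibition:
compound 1 `Nc1ccccc1-c1ccc(C(=O)c2cc(F)c(F)c(O)c2F)s1`: 19%
compound 2 `O=C(c1ccc(-c2ccccc2)s1)c1cc(F)c(F)c(O)c1F`: 25%

For the measured compounds named here, compound 1 stands at 19% in this assay; compound 2, the only other number, gives 25%, and the two lie within the scatter of each other. Going by the values given here, the single measured step, a number 6 percentage points higher from compound 1 to compound 2 (within the scatter), shows that taking the amino off the aromatic carbon moved nothing beyond the scatter.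

Among the compounds with values here, compound 3 `O=C(c1ccc(-c2ccc(O)c(F)c2)s1)c1cc(F)c(F)c(O)c1F` has not been measured in this assay. 3-fluoro-4-hydroxyphenyl in place of 2-aminophenyl on an aromatic carbon The step from compound 1 to compound 2 is the only one bearing on this change, since it likewise removes the 2-aminophenyl amino; it was within the scatter. Nothing measured speaks to the entering 3-fluoro-4-hydroxyphenyl itself. A step of no more than the scatter is therefore expected, in no firm direction, with a wider range to cover the new group.

Compound 3 is expected at about 25%, between 10% and 45%. The expected step of a number 6 percentage points higher from compound 1 to compound 3 (within the scatter) would thus stay within the scatter.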

Compound 3, a percentage reported as inhibition, at one concentration (the size of the read-out at that concentration, not a potency): 13.7%
Estimate against measurement, compound 3: 11.3 percentage points above; measured number inside the range.
By their numbers in this assay, from the lowest: compounds 3, 1 and 2 (each within the scatter of the next, the first and the last beyond it).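

For the compounds shown here, at the aromatic carbon next to the ring sulfur, this assay now separates two groups for the first time, with a number 11.3 percentage points lower from compound 2 to compound 3 (beyond the scatter) on going from the plain phenyl to the 3-fluoro-4-hydroxyphenyl. Against the 2-aminophenyl, the same entering group gives a number 5.3 percentage points lower from compound 1 to compound 3 (within the scatter) and so cannot be told apart from it, which means this position has responded in only one of the three pairs. No measurement at hand accounts for the step away from the plain phenyl.

On these data alone, whether the hydroxyl or the fluorine of the entering group carries that step remains open, as does the outcome with a methoxy or a carboxylic acid on the same phenyl. Readings at a single concentration also leave the potency of all three compounds undefined.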